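The source may report more compounds than this note shows. Statements on the series, on what has been measured and on what is new or still open speak of the compounds shown alone.

Measured so far:
- compound 1 `CCC(c1ccc(-c2cscc2C)cc1)n1ccnc1`: 84%
- compound 2 `CCC(c1ccc(-c2ccsc2Cl)cc1)n1ccnc1`: 85%

Compound 1 holds the lower of the two numbers in an assay for inhibition of steroid 17-alpha-hydroxylase/17,20 lyase (Homo sapiens), using NADPH, tested at 2 uM (on this read-out lower numbers stand for a weaker effect and higher numbers for a stronger effect at the one concentration tested), and compound 2 sits within the scatter of it, as shown by a number 1 percentage points higher from compound 1 to compound 2 (within the scatter). Compound 3 `CCC(c1ccc(-c2cscc2C)cc1F)n1ccnc1` differs from compound 1 by fluoro in place of hydrogen on an aromatic carbon. Going by the values given here, the one measured step changes a different part of the molecule, so no step bears directly on this change. Since both measured compounds give high inhibition at the tested concentration, the step of a number 2 percentage points lower from compound 1 to compound 3 (within the scatter) is expected to be small, with no change beyond the scatter. Compound 3 is therefore estimated at 82%, between 68% and 93%.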

Compound 3, a percentage reported as inhibition, at one concentration (the size of the read-out at that concentration, not a potency): 92%
Beside the measured number, compound 3's estimate is 10 percentage points below it; the measured number falls inside the stated range.
By their numbers in this assay, from the lowest: compounds 1, 2 and 3 (each within the scatter of the next).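

In this assay, fluoro in place of hydrogen on this aromatic carbon of the six-membered ring gives a number 8 percentage points higher from compound 1 to compound 3 (within the scatter), so this position takes a fluorine with no change that stands out from the scatter. The earlier step showed this only for a change in the 4-methylthiophen-3-yl group, not for a change on the six-membered ring. Nothing measured here gives a reason for this result.

On these data alone, whether a methoxy group or an amine on this same carbon would leave the read-out equally undisturbed remains open. So does the effect of fluoro on the other carbons of this ring.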